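This account rests on a few compounds, and the source may have more. Where it says the series, first, only, none or still open, it means among the compounds named here.

Of the compounds shown here, three have so far been measured in a functional assay on DU-145 cells (Homo sapiens) for cytotoxicity, read by MTT assay, with a stated time of 48 h; a higher number here means a weaker inhibitor, a lower number a stronger inhibitor. Compound 1 `N#Cc1ccc(CN(C(=O)Nc2cc(C(F)(F)F)cc(C(F)(F)F)c2)n2cnnc2)cc1` gives 11800 nM, compound 2 `O=C(NCc1ccccc1)N(Cc1ccccn1)n1cnnc1` gives 21200 nM, and compound 3 `COc1ccc(OC)c(CN(C(=O)NC2CCCCC2)n2cnnc2)c1` gives 29800 nM. Compound 2 thus sits second highest among the three numbers; its nearest neighbour is compound 3 and its furthest is compound 1, and both of those gaps lie within the usual scatter of repeated measurements, so the three compounds cannot be told apart on these numbers. All three numbers are large, which for this read-out means weak inhibition.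

Compound 4 `O=C(Nc1ccccc1)N(Cc1ccccn1)n1cnnc1` has not yet been measured. It differs from compound 2 in one place only: phenyl in place of benzyl on an amide-type nitrogen. Within the data shown here, no measured pair shows what this change does, and the three measured compounds give no foothold for a direction. The step from compound 2 to compound 4 is therefore expected to stay within the scatter, a 1.0-fold higher number from compound 2 to compound 4 (0.02 log units; within the scatter). Compound 4 is estimated at 22000 nM, with a likely range from 8000 nM to 60000 nM.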

Compound 4, half-maximal inhibitory concentration: 20200 nM
The estimate for compound 4 lay 1.1-fold (0.04 log units) above the measured number; the range from low to high includes it.
By their numbers in this assay, from the lowest: compounds 1, 4, 2 and 3 (each within the scatter of the next, the first and the last beyond it).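

This is the only pair shown that differs in one place, so it gives the first direct reading at this position. In this assay, phenyl in place of benzyl on an amide-type nitrogen gives a 1.0-fold lower number from compound 2 to compound 4 (0.02 log units; within the scatter). The ring on this nitrogen can therefore be attached either way on this core with no readable difference in this assay, and no measurement shown offers an explanation for that.

This single pair cannot show whether other groups on the same nitrogen would behave alike, such as a longer chain like phenylethyl, or a phenyl ring carrying an amine or a carboxylic acid. It also leaves open whether the same swap would give a similar result if the rest of the molecule were different.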